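Solubility of a biphenyl glycoside series: predicting compound 4

The compounds below may be only part of what the source reports. "The series", "measured", "known", "first", "only" and "open" are said of these compounds alone.

Compound 1 `OC[C@H]1O[C@H](Oc2ccc(-c3ccccc3)cc2Cl)[C@@H](O)[C@@H](O)[C@@H]1O`: 5.5 ug/mL
Compound 2 `N#Cc1cccc(-c2ccc(O[C@H]3O[C@H](CO)[C@@H](O)[C@H](O)[C@@H]3O)c(Cl)c2)c1`: 227 ug/mL
Compound 3 `OC[C@H]1O[C@H](Oc2ccc(-c3ccc(Cl)cc3)cc2Cl)[C@@H](O)[C@@H](O)[C@@H]1O`: 3.5 ug/mL

In a physicochemical assay for solubility, measured as kinetic solubility, with a stated time of 15 h, at pH 7.4 (a lower number here means a less soluble compound, a higher number a more soluble compound), compound 3 gives the lowest of the three numbers. Its nearest neighbour is compound 1, from which the step of a 1.6-fold lower number from compound 1 to compound 3 (0.20 log units; within the scatter) is within the scatter; the furthest is compound 2, from which the step of a 65-fold lower number from compound 2 to compound 3 (1.81 log units; beyond the scatter) is large. Compound 4 `Cc1ccccc1-c1ccc(O[C@H]2O[C@H](CO)[C@@H](O)[C@H](O)[C@@H]2O)c(Cl)c1` differs from compound 3 in one place: 2-methylphenyl in place of 4-chlorophenyl on an aromatic carbon.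

For the measured compounds named here, two measured steps bear on this change. The step of a 1.6-fold lower number from compound 1 to compound 3 (0.20 log units; within the scatter) shows that a chloro group in place of hydrogen on the outer aromatic ring left this assay unchanged within the scatter. The step of a 41-fold higher number from compound 1 to compound 2 (1.62 log units; beyond the scatter) shows that a cyano group at the same ring produced a large rise. Going by the values given here, compound 4 carries neither a chloro nor a cyano group on that ring, only a methyl, so no measured step points toward a large movement in either direction. The account therefore expects compound 4 to sit close to compound 3 and compound 1, with a step of a 2.3-fold higher number from compound 3 to compound 4 (0.36 log units; beyond the scatter) that may not exceed the scatter. For compound 4 the estimate in this assay is 8 ug/mL, within a range from 2.5 ug/mL to 30 ug/mL.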

Compound 4, solubility: 135 ug/mL
Estimate against measurement, compound 4: 17-fold (1.23 log units) below, outside the stated range (above it).
By their numbers in this assay, from the lowest: compounds 3 and 1 (each within the scatter of the next); then compounds 4 and 2 (each within the scatter of the next).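

In this assay, the outer ring proves able to carry a large rise without a nitrile: the change to 2-methylphenyl gives (a 39-fold higher number from compound 3 to compound 4 (1.59 log units; beyond the scatter)), and methyl in place of hydrogen gives (a 25-fold higher number from compound 1 to compound 4 (1.39 log units; beyond the scatter)). Compound 2 and compound 4 lie within the scatter of each other (a 1.7-fold lower number from compound 2 to compound 4 (0.23 log units; within the scatter)), so 3-cyanophenyl and 2-methylphenyl reach the same range, and a group on the outer ring can lift the number without being a nitrile, though compound 3, with its 4-chlorophenyl, goes against any rule that every such group does so. Nothing measured here accounts for these steps.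

The compounds shown leave open whether the rise stays with the methyl group wherever it stands on the outer ring, and whether a chloro group in the place that methyl holds in compound 4 would follow compound 4 or compound 3. They also leave open whether an ethyl group, a methoxy group or an amine on that ring would give a number near compound 4 or near compound 1.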